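The compounds below may be only part of what the source reports. "The series", "measured", "known", "first", "only" and "open" are said of these compounds alone.

Measured compounds, values in a functional assay on HT-29 cells (Homo sapiens) for inhibition, read by MTT assay, with a stated time of 48 h; on this read-out lower numbers stand for stronger inhibition and higher numbers for weaker inhibition:
compound 1 `COc1cc(/C=C/c2ccc(NC(=O)/C=C/c3ccc(C#N)cc3)cc2)cc(OC)c1` — 3320 nM
compound 2 `COc1cc(/C=C/c2ccc(NC(=O)/C=C/c3ccc(F)cc3)cc2)cc(OC)c1` — 11600 nM

Compound 2 holds the highest of the two numbers; its nearest neighbour is compound 1, reached by a 3.5-fold higher number from compound 1 to compound 2 (0.54 log units; beyond the scatter). Compound 3 `COc1cc(/C=C/c2ccc(NC(=O)/C=C/c3ccc(Cl)cc3)cc2)cc(OC)c1` differs from compound 2 by chloro in place of fluoro on an aromatic carbon. Among the measured compounds shown here, no measured step covers a halogen-for-halogen exchange at this position; the one step known concerns the cyano-to-fluoro exchange, so it bears only loosely. For compound 3 the expected step is a 1.5-fold lower number from compound 2 to compound 3 (0.19 log units; within the scatter), a slight move toward lower numbers at most, within or near the scatter. The estimate for compound 3 is 7500 nM, range 3000 nM to 20000 nM.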

Compound 3, half-maximal inhibitory concentration: 10300 nM
Estimate against measurement, compound 3: 1.4-fold (0.14 log units) below; the measured number falls inside the stated range.
By their numbers in this assay, from the lowest: compound 1; then compounds 3 and 2 (each within the scatter of the next).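

Swapping one halogen for the other at this position does not separate the compounds, with a 1.1-fold lower number from compound 2 to compound 3 (0.05 log units; within the scatter). Chloro in place of cyano gives a 3.1-fold higher number from compound 1 to compound 3 (0.49 log units; beyond the scatter), so the lower number of compound 1 is now set against two halogens rather than fluoro alone. Nothing available accounts for this grouping.

As far as these compounds go, whether the lower number is particular to the nitrile remains open. An amine, a carboxylic acid or a trifluoromethyl group at this position would test how far it extends.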